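The source may hold more compounds than are shown below. What is called first, only, known or untested is meant among the compounds shown, and "the series" means these compounds.

Measured compounds:
Compound 1 `COc1ccc(/C(COc2ccc(Br)cc2)=N\NC(N)=S)cc1` reads < 25400 nM as a limit
Compound 2 `NC(=S)N/N=C(\COc1ccccc1)c1ccc(Br)cc1` reads 54900 nM as a number

In an ADME assay on L929 cells (Mus musculus) for cytotoxicity, read by resazurin assay, with a stated time of 96 h (on this read-out lower numbers stand for higher toxicity in this test and higher numbers for lower toxicity in this test), compound 2 gives 54900 nM as the only number shown. Compound 1 stands at < 25400 nM as a limit of the assay and not a number. Compound 3 `CC(C)c1ccc(OC/C(=N\NC(N)=S)c2ccc(Br)cc2)cc1` has isopropyl in place of hydrogen on an aromatic carbon, para to a large group isopropyl in place of hydrogen on an aromatic carbon in its structure. Among the compounds with values here, no measured step shows what such a change does in this assay on these compounds. A modest move towards higher toxicity in this test is expected, an estimated 2.0-fold lower number from compound 2 to compound 3 (0.29 log units; within the scatter) and so not far beyond the scatter. Compound 3 is estimated at 28000 nM with a range of 10000 nM to 65000 nM as the expected span.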

Compound 3, half-maximal cytotoxic concentration: 24600 nM
For compound 3 the middle estimate is 1.1-fold (0.06 log units) above the measured one; low and high end bracket the measured number.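

Isopropyl in place of hydrogen on an aromatic carbon, para to a large group, gives a 2.2-fold lower number from compound 2 to compound 3 (0.35 log units; beyond the scatter) in this assay. Within the data shown here, this is the first measured step at this position, and it shows a modest move towards higher toxicity in this test. Compound 1 stands only as a limit of the assay, and it differs from compound 2 in more than one place, so it adds no step: the limit of < 25400 nM in this assay, at which 1 of the 3 values shown sits.

As far as these compounds go, whether methyl, an amine or a carboxylic acid at this position would move the number the same way stays open. So does whether isopropyl would do the same on another core.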